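Hydroxyphenyl variation in a bromobenzylthio enone series

The source may hold more compounds than are shown below. What is called first, only, known or untested is meant among the compounds shown, and "the series" means these compounds.

Measured so far:
compound 1 `O=C(/C(=C\c1ccc(O)c([N+](=O)[O-])c1)SCc1ccc(Br)cc1)c1ccc(C(F)(F)F)cc1`: 10000 nM
compound 2 `O=C(/C(=C\c1cc(Br)c(O)c(Br)c1)SCc1ccc(Br)cc1)c1ccc(Br)cc1`: 1000 nM
compound 3 `O=C(/C(=C\c1cc(Cl)c(O)c(Cl)c1)SCc1ccc(Br)cc1)c1ccc(Br)cc1`: 10000 nM

In a functional assay on DU-145 cells (Homo sapiens) for inhibition, read by trypan blue exclusion, with a stated time of 96 h (a lower number here means a stronger inhibitor of growth, a higher number a weaker inhibitor of growth), compound 3 stands level with compound 1 at the digits given, the two together the highest numbers of the three; compound 2 gives the lowest. Among the measured compounds shown here, the one step between single-change neighbours is a 10-fold higher number from compound 2 to compound 3 (1.00 log units; beyond the scatter).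

Compound 4 `O=C(/C(=C\c1ccc(O)c([N+](=O)[O-])c1)SCc1ccc(Br)cc1)c1ccc(Br)cc1` differs from compound 3 as follows. 4-hydroxy-3-nitrophenyl in place of 3,5-dichloro-4-hydroxyphenyl on a double-bonded chain carbon bound to a double-bonded chain carbon

For the measured compounds named here, no measured step bears directly on this change. Compound 1 carries the same 4-hydroxy-3-nitrophenyl and sits at the same level as compound 3, so no step beyond the scatter is expected; compound 4 is estimated at 10000 nM (range 3000 nM to 40000 nM), meaning an expected step of no change at the digits printed from compound 3 to compound 4 (within the scatter).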

Compound 4, concentration for 50% growth inhibition: 10000 nM
Estimate against measurement, compound 4: no gap at the digits printed; low and high end bracket the measured number.
By their numbers in this assay, from the lowest: compound 2; then compounds 1, 3 and 4 (each within the scatter of the next).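

In this assay the 4-hydroxy-3-nitrophenyl and 3,5-dichloro-4-hydroxyphenyl groups now compare directly on the shared core (no change at the digits printed from compound 3 to compound 4 (within the scatter)). Against the 3,5-dibromo-4-hydroxyphenyl group, the 4-hydroxy-3-nitrophenyl group repeats the separation seen for the dichloro group (a 10-fold higher number from compound 2 to compound 4 (1.00 log units; beyond the scatter)), so among these three groups on this core only the dibromo group gives the lower number. Among the compounds shown here, the first reading of bromo in place of trifluoromethyl on an aromatic carbon shows no separation (no change at the digits printed from compound 1 to compound 4 (within the scatter)).

On these data alone, how an amine or a carboxylic acid in place of the hydroxyphenyl group would read remains open. No measurement available here accounts for the lower number of the dibromo compound.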